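The source may hold more compounds than are shown below. What is called first, only, known or untested is meant among the compounds shown, and "the series" means these compounds.

Compound 1 `Cc1ccc(Nc2ncc3c(n2)N(C)C(=O)N(c2cc(NC(=O)c4cccc(C(F)(F)F)c4)ccc2C)C3)cc1C` and compound 2 `Cc1ccc(Nc2ncc3c(n2)N(C)C(=O)N(c2cc(NC(=O)c4cccc(C(F)(F)F)c4)ccc2C)C3)cc1` share one core and differ in a single place, (hydrogen in place of methyl on an aromatic carbon). In a functional assay on K562 cells (Homo sapiens) for antiproliferative activity, read by CellTiter-Glo and CCK-8 assay, with a stated time of 72 h (on this read-out higher numbers stand for weaker inhibition of growth and lower numbers for stronger inhibition of growth), compound 1 gives 17 nM and compound 2 gives 18 nM, a step of a 1.1-fold higher number from compound 1 to compound 2 (0.02 log units; within the scatter). Compound 3 `Cc1cc(C)cc(C(=O)Nc2ccc(C)c(N3Cc4cnc(Nc5ccc(C)c(N)c5)nc4N(C)C3=O)c2)c1` is built on a different core; the difference between the two cores is not broken down here. In this assay compound 3 gives 26 nM. Compound 4 `Cc1cccc(C(=O)Nc2ccc(C)c(N3Cc4cnc(Nc5ccc(C)c(N)c5)nc4N(C)C3=O)c2)c1` differs from compound 3 by hydrogen in place of methyl on an aromatic carbon. For the measured compounds named here, this is the same kind of change as the one from compound 1 to compound 2, though not the same: in compound 1 the leaving methyl sits ortho to a methyl group, in compound 3 it sits meta to a methyl group. Compound 4 is expected to give about 28 nM in this assay, between 12 nM and 65 nM, because a 1.1-fold higher number from compound 1 to compound 2 (0.02 log units; within the scatter) stayed within the scatter. The expected step, a 1.1-fold higher number from compound 3 to compound 4 (0.03 log units; within the scatter), rests on that earlier step alone.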

Compound 4, concentration for 50% growth inhibition: 68.8 nM
Estimate against measurement, compound 4: 2.5-fold (0.39 log units) below, and the stated range ends below it.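

In this assay, going from 3,5-dimethylphenyl to 3-methylphenyl gives a 2.6-fold higher number from compound 3 to compound 4 (0.42 log units; beyond the scatter). For the compounds shown here, only this step lies beyond the scatter, yet the gap between it and the earlier step does not, so the two steps cannot be told apart: the same change on two cores in this assay, a 1.1-fold higher number (0.02 log units; within the scatter) from compound 1 to compound 2 and a 2.6-fold higher number (0.42 log units; beyond the scatter) from compound 3 to compound 4, 2.5-fold (0.40 log units) apart, within the scatter of two such steps. The data therefore show neither that the change carries over unaltered nor that the core alters it, and with one pair on each core, and the methyl leaving a different place in each, they give no rule.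

The compounds shown leave open how an amine, a methoxy group or a longer chain in place of that methyl would read in this assay. They also leave open what the same change does at one identical place on both cores.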